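A few compounds are considered here, and "the series" means these few. Any claim that something is new, unique, unknown or untested is made for them only; others in the source may bear on it.

Compound 1, with the structure `COc1ccc(CCCCCCCCOc2ccc(C[S+]([O-])c3ccccc3)nc2/C=C/C(=O)O)cc1`, sits at the stronger end of the two results gathered so far. In an assay for binding affinity to leukotriene B4 receptor 1 (Homo sapiens) (a lower number here means a stronger inhibitor, a higher number a weaker inhibitor), compound 1 gives 37 nM. Among the compounds with values here, the only other measured compound, compound 2, with the structure `COc1ccc(CCCCCCOc2ccc(CC(O)c3cccc(C(=O)O)c3)nc2/C=C/C(=O)O)cc1`, differs from compound 1 in several places at once: a shorter chain, a different linker between the core and the outer ring, and a carboxy group on that outer ring. In this assay compound 2 gives 165 nM, a weaker result than that of compound 1 and one that lies beyond the usual scatter of repeated measurements. Several features change together. No single one of them can be credited with the gap.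

Compound 3, with the structure `COc1ccc(CCCCCCCCOc2ccc(C[S+]([O-])c3cccc(C(=O)O)c3)nc2/C=C/C(=O)O)cc1`, is not yet measured. It differs from compound 1 in one place only: carboxy in place of hydrogen on an aromatic carbon. Within the data shown here, no measured pair shows this single change alone, so the step can only be judged from the two values on hand. The change from compound 1 to compound 3 is expected to be modest, from within the scatter to a small weakening, giving a 1.5-fold higher number from compound 1 to compound 3 (0.17 log units; within the scatter). For compound 3 in this assay a value of 55 nM is estimated, with a range from 15 nM to 200 nM.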

Compound 3, inhibition constant: 151 nM
Beside the measured number, compound 3's estimate is 2.7-fold (0.44 log units) below it; the measured number falls inside the stated range.
By their numbers in this assay, from the lowest: compound 1; then compounds 3 and 2 (each within the scatter of the next).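

The phenyl to 3-carboxyphenyl change can now be read on its own, with the rest of the molecule held fixed: in this assay it gives a 4.1-fold higher number from compound 1 to compound 3 (0.61 log units; beyond the scatter) and thus a real weakening. This ring position, on an aromatic carbon meta to a large group, is therefore not indifferent to what it carries, since replacing one hydrogen with a carboxy group of just 3 heavy atoms is enough to produce a clear loss. No measurement here bears on why the number rises.

On these data alone, it remains open whether the loss belongs to the carboxy group itself or would also follow from other groups at this place, such as a methyl ester, an amide or a simple methyl group, and whether a carboxy group elsewhere on the same ring would behave the same way. It is also unknown whether the step would keep its size on the shorter chain and the hydroxy-bearing linker of compound 2, since compound 2 has no partner that differs from it in this one place.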